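This account rests on a few compounds, and the source may have more. Where it says the series, first, only, none or still open, it means among the compounds named here.

Working notes on the series.

Of the compounds shown here, two carry a number so far. Compound 1 `Cc1ccc(N2CCN(C(=O)[C@@H]3CN(C4CCOCC4)C[C@H]3c3ccc(Cl)cc3)CC2)c([C@@H](NC(=O)CN)C(C)C)c1` is measured in a functional assay on CHO cells for agonist activity at Melanocortin receptor 4 (Homo sapiens), read by cAMP accumulation (on this read-out lower numbers stand for an effect already at smaller amounts and higher numbers for an effect only at larger amounts of compound), and gives 9.1 nM. Compound 2 `CC(C)[C@H](NC(=O)CCN(C)C)c1cccc(F)c1N1CCN(C(=O)[C@@H]2CN(C(C)C)C[C@H]2c2ccc(Cl)cc2)CC1` differs from it in more than one place; in this assay compound 2 gives 20 nM. Of the two numbers compound 1 holds the lower one, and the gap to compound 2 lies beyond the usual scatter of this kind of measurement, so compound 1 is the stronger of the two on this read-out. Since the two differ in several places at once, nothing is drawn from that gap for any single change.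

Compound 3 `Cc1ccc(N2CCN(C(=O)[C@@H]3CN(C4CCOCC4)C[C@H]3c3ccc(Cl)cc3)CC2)c([C@@H](NC(=O)[C@@H](C)N)C(C)C)c1` is not yet measured. It keeps the whole of compound 1 apart from one change: methyl in place of hydrogen on a saturated chain carbon bound to an amine nitrogen and a carbonyl carbon. For the measured compounds named here, this is the smallest kind of alteration, and the series offers no measured step of this sort to lean on.

The expectation is that the step from compound 1 to compound 3 stays within the scatter, with a 1.1-fold lower number from compound 1 to compound 3 (0.06 log units; within the scatter) in this assay, in no firm direction. Compound 3 is therefore estimated at 8 nM, within a range of 3 nM to 25 nM.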

Compound 3, half-maximal effective concentration: 17 nM
Estimate against measurement, compound 3: 2.1-fold (0.33 log units) below; low and high end bracket the measured number.
By their numbers in this assay, from the lowest: compounds 1, 3 and 2 (each within the scatter of the next, the first and the last beyond it).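

In this assay, for the compounds shown here, the first measured step at this position reads a 1.9-fold higher number from compound 1 to compound 3 (0.27 log units; within the scatter). Methyl in place of hydrogen on a saturated chain carbon bound to an amine nitrogen and a carbonyl carbon, which turns aminomethyl into 1-aminoethyl, therefore gives no difference that can be told from the scatter, something no earlier pair could show, since the only other measured compound differs from compound 1 in several places. No measured evidence bears on this result, so the step stands as an observation without an explanation.

The compounds shown leave open how this carbon responds to groups larger than methyl, such as ethyl, isopropyl or a longer chain ending in an amine, and whether the opposite configuration of the 1-aminoethyl group reads the same. Also open, from the compounds shown here alone, is what happens when the amine itself is exchanged, for instance for a dimethylamine or a hydroxyl group, with the rest of compound 1 kept unchanged.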